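Chain extension on the carbamate of a selenocyanate series

The compounds below may be only part of what the source reports. "The series", "measured", "known", "first", "only" and "open" are said of these compounds alone.

Among the measured compounds shown here, two measured compounds define the series so far. Compound 1 `CCCCOC(=O)Nc1ccc([Se]C#N)cc1` is the lower of the two numbers in a functional assay on CCRF-CEM cells (Homo sapiens) for cytotoxicity, read by MTT assay, with a stated time of 72 h (on this read-out lower numbers stand for stronger inhibition of growth and higher numbers for weaker inhibition of growth), where compound 1 gives 6500 nM. The other measured compound, compound 2 `CCOC(=O)Nc1ccc([Se][Se]c2ccc(NC(=O)OCC)cc2)cc1`, is a diselenide carrying two ethyl carbamates, and in this assay compound 2 gives 24600 nM; the gap between the two values lies beyond the scatter, but the two structures differ in more than one place, so no single step can be read from them.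

Compound 3 `CCCCCCOC(=O)Nc1ccc([Se]C#N)cc1` differs from compound 1 by ethyl in place of hydrogen on a saturated chain carbon, four bonds along the chain from an oxygen next to a carbonyl group. For the measured compounds named here, no measured pair shows what lengthening this chain does. The step from compound 1 to compound 3 is therefore expected to be a 1.3-fold lower number from compound 1 to compound 3 (0.11 log units; within the scatter), small and not clearly beyond the scatter. In this assay compound 3 is estimated at 5000 nM, with a range of 2000 nM to 15000 nM.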

Compound 3, concentration for 50% growth inhibition: 19700 nM
Estimate against measurement, compound 3: 3.9-fold (0.60 log units) below, outside the stated range (above it).
By their numbers in this assay, from the lowest: compound 1; then compounds 3 and 2 (each within the scatter of the next).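

This gives the series its first reading at a single place: in this assay the change to the carbamate chain produces a 3.0-fold higher number from compound 1 to compound 3 (0.48 log units; beyond the scatter) and so weakens growth inhibition, a modest step that lies beyond the scatter. Ethyl in place of hydrogen on a saturated chain carbon, four bonds along the chain from an oxygen next to a carbonyl group, is therefore not tolerated without cost in this selenocyanate pair, though a single pair sets no trend along the chain. No measured property in hand bears on this step.

On these data alone, a longer chain such as octyl could extend the step or leave it unchanged, and an amine or a carboxylic acid at the chain end remains untested here. As far as these compounds go, whether the same lengthening has a comparable effect on the diselenide of compound 2 also stays open.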